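The source may report more compounds than this note shows. Statements on the series, on what has been measured and on what is new or still open speak of the compounds shown alone.

Compound 1 `CC(Nc1ccccc1Oc1ccccc1)=C1C(=O)CC(c2ccccc2)CC1=O` is the unsubstituted parent; in a functional assay on CCRF-CEM cells (Homo sapiens) for antiproliferative activity, read by cell counting, with a stated time of 96 h (on this read-out higher numbers stand for weaker inhibition and lower numbers for stronger inhibition), compound 1 gives 170 nM. Compound 2 `CC(Nc1ccccc1Oc1cccc(F)c1)=C1C(=O)CC(c2ccccc2)CC1=O` carries a fluoro in place of hydrogen on an aromatic carbon, and in this assay compound 2 gives 170 nM. The step of no change at the digits printed from compound 1 to compound 2 (within the scatter) shows that this fluoro changed nothing the measurement could resolve, so compound 2 stands level with compound 1. Compound 3 `CC(Nc1ccccc1Oc1cccc(N)c1)=C1C(=O)CC(c2ccccc2)CC1=O` differs from compound 2 in a single place: amino in place of fluoro on an aromatic carbon. Among the compounds with values here, no measured step swaps one aromatic substituent for another, so the only guide is the flat step no change at the digits printed from compound 1 to compound 2 (within the scatter), which suggests that this region of the molecule tolerates small changes. A step of about a 1.3-fold higher number from compound 2 to compound 3 (0.11 log units; within the scatter) is therefore expected, small and within the scatter or only just beyond it. Compound 3 is estimated at 220 nM in this assay, with a likely range from 80 nM to 600 nM.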

Compound 3, half-maximal inhibitory concentration: 42 nM
For compound 3 the middle estimate is 5.2-fold (0.72 log units) above the measured one; measured number below the stated range.
By their numbers in this assay, from the lowest: compound 3; then compounds 1 and 2 (each within the scatter of the next).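

In this assay this position turns out to respond to change: amino in place of fluoro brings a 4.0-fold lower number from compound 2 to compound 3 (0.61 log units; beyond the scatter) and amino in place of hydrogen brings a 4.0-fold lower number from compound 1 to compound 3 (0.61 log units; beyond the scatter) on the same ring. The flat result for fluoro therefore did not mean that the position tolerates every small change, since the shift appears with the 3-aminophenoxy group, the only one of the three carrying a hydrogen-bond donor. Nothing available here explains why the amino group lowers the number.

The compounds shown do not tell whether this shift is specific to the amino group or would also appear with a hydroxyl, a methylamino or an acetamide group at this place. They also leave open whether an amino group would have the same effect elsewhere on this ring.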